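The source may report more compounds than this note shows. Statements on the series, on what has been measured and on what is new or still open speak of the compounds shown alone.

Compound 1: `Cc1cnc(-c2ccc(Cl)c(C(=O)NCC3(O)CCCCCC3)c2)cn1` — 22 nM
Compound 2: `O=C(NCC1(O)CCCC(F)(F)C1)c1cc(-c2ncc(F)cn2)ccc1Cl` — 51 nM

Of the compounds shown here, two have been measured in a functional assay on HEK293 cells for antagonist activity at P2X purinoceptor 7 (Homo sapiens); on this read-out higher numbers stand for weaker inhibition and lower numbers for stronger inhibition. Compound 1 gives 22 nM, the lower of the two numbers. Compound 2 gives 51 nM; the gap between compound 2 and compound 1 is beyond the usual scatter, so compound 1 stands as the stronger inhibitor of the pair. The two also differ in more than one part of their structure, so no single change can be read from them.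

Compound 3 is `COc1ccc(-c2ccc(Cl)c(C(=O)NCC3(O)CCCCCC3)c2)nc1` and has not yet been measured. It differs from compound 1 in one place: 5-methoxypyridin-2-yl in place of 5-methylpyrazin-2-yl on an aromatic carbon. Among the compounds with values here, no measured pair shows this exchange, so its effect is unknown. Both groups are aromatic rings of similar size carrying one substituent, and such swaps often leave potency close to where it was. The step from compound 1 to compound 3 in this assay is expected to be small, a 1.4-fold higher number from compound 1 to compound 3 (0.13 log units; within the scatter), not clearly beyond the scatter in either direction. Compound 3 is therefore estimated at 30 nM, with a likely range from 10 nM to 100 nM.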

Compound 3, half-maximal inhibitory concentration: 213 nM
Beside the measured number, compound 3's estimate is 7.1-fold (0.85 log units) below it; the measured number lies above the stated range.
By their numbers in this assay, from the lowest: compound 1; then compound 2; then compound 3.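

In this assay, the aromatic carbon para to the chloro group does not accept these two rings equally: 5-methoxypyridin-2-yl in place of 5-methylpyrazin-2-yl gives a 9.7-fold higher number from compound 1 to compound 3 (0.99 log units; beyond the scatter), a step toward weaker inhibition that lies beyond the usual scatter. The exchange alters two things at once, the ring (2 hetero atoms leave, 1 enters) and its substituent (methyl leaves, methoxy enters), even though the count of hydrogen-bond acceptors stays at 2, so this one step cannot be divided between them. No measurement here explains the loss.

Still open, from the compounds shown here alone, is whether the ring or the substituent carries the step. A 5-methoxypyrazin-2-yl or a 5-methylpyridin-2-yl group on the core of compound 1 would separate the two changes.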